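The compounds below may be only part of what the source reports. "The series", "measured", "known", "first", "only" and "open" are said of these compounds alone.

Measured so far in a functional assay on MOLT-4 cells (Homo sapiens) for cytotoxicity, read by CCK-8 assay, with a stated time of 24 h; a lower number here means a stronger inhibitor, a higher number a weaker inhibitor:

- compound 1, `C=CC(=O)N1C(=O)CC(c2ccc(C(F)(F)F)cc2)Sc2ccccc21`: 76300 nM
- compound 2, `C=CC(=O)N1C(=O)CC(c2ccc(OC)cc2)Sc2ccccc21`: 83200 nM

Compound 1 holds the lower of the two numbers, but the step to its nearest neighbour, a 1.1-fold higher number from compound 1 to compound 2 (0.04 log units; within the scatter), lies within the scatter, so the two compounds cannot be placed in order on this evidence. Both are weak inhibitors in this assay.

Compound 3, `C=CC(=O)N1C(=O)CC(c2ccc(Br)cc2)Sc2ccccc21`, is the next member of the series. It differs from compound 1 by bromo in place of trifluoromethyl on an aromatic carbon. Within the data shown here, the only measured step that bears on this change is the swap at the same aromatic carbon from compound 1 to compound 2, which gave a 1.1-fold higher number from compound 1 to compound 2 (0.04 log units; within the scatter) and stayed within the scatter. Among the measured compounds shown here, no step involving a bromo group has been measured, so the expectation rests on that single comparison.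

The expected step is therefore a 1.0-fold higher number from compound 1 to compound 3 (0.02 log units; within the scatter), nothing beyond the scatter. For compound 3 the estimate in this assay is 80000 nM, with a range of 40000 nM to 160000 nM.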

Compound 3, half-maximal inhibitory concentration: 106000 nM
Compound 3: middle estimate off by 1.3-fold (0.12 log units), on the low side; measured number inside the range.
By their numbers in this assay, from the lowest: compounds 1, 2 and 3 (each within the scatter of the next).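

Bromo is the third group at this aromatic carbon, para to a large group, and in this assay the series still does not separate: compound 3 stays within the scatter of both neighbours (a 1.4-fold higher number from compound 1 to compound 3 (0.14 log units; within the scatter); a 1.3-fold higher number from compound 2 to compound 3 (0.11 log units; within the scatter)). Trifluoromethyl, with 4 heavy atoms, and bromo, with 1 heavy atom, cannot be placed in order here, so this difference in heavy-atom count has no readable effect across this pair. Nothing measured here offers an explanation for the flat result.

From the compounds shown here alone, whether any group at this carbon can move the number beyond the scatter remains open, as an amine, a carboxylic acid or a longer chain would test a different kind of substituent. Also open, going by these compounds, is whether changes elsewhere on the shared core matter more than this position.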